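Side Chain Swap on a Shared Core: Cytotoxicity Outlook

A few compounds are considered here, and "the series" means these few. Any claim that something is new, unique, unknown or untested is made for them only; others in the source may bear on it.

Compound 1, `N#Cc1c(Cn2c(=O)n(C3CC3)c3ccncc32)nc2cc(Cl)ccn12`, in an ADME assay on HEp-2 cells (Homo sapiens) for cytotoxicity, read by CCK-8 assay, with a stated time of 6 days (a lower number here means that less compound is tolerated, a higher number that more compound is tolerated), gives 22500 nM.
Compound 2, `O=c1n(Cc2nc3cc(Cl)ccn3c2CO)c2cnccc2n1C1CC1`, in this assay gives > 100000 nM, which is a limit of the assay.
Compound 3, `CS(=O)(=O)CCNC(=O)c1c(Cn2c(=O)n(C3CC3)c3ccncc32)nc2cc(Cl)ccn12`, in this assay gives > 100000 nM, again a limit of the assay.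

Compound 3 therefore stands at the limit, and so does compound 2, as the limit of > 100000 nM in this assay, at which 2 of the 3 values shown sit, shows; only compound 1 gives a number. The step of an at least 4.4-fold higher number from compound 1 to compound 3 (0.64 log units; beyond the scatter) and the step of an at least 4.4-fold higher number from compound 1 to compound 2 (0.64 log units; beyond the scatter) both run the same way, while the step that the two limits leave unreadable from compound 2 to compound 3 cannot be read.

Compound 4, `O=C(CCc1c(Cn2c(=O)n(C3CC3)c3ccncc32)nc2cc(Cl)ccn12)NCCO`, differs from compound 3 in one place: 2-((2-hydroxyethyl)carbamoyl)ethyl in place of (2-(methylsulfonyl)ethyl)carbamoyl on an aromatic carbon. The chain that enters carries a hydroxyethyl amide; the chain that leaves carries a methylsulfonyl amide.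

For the measured compounds named here, the steps that bear on this change are those from compound 1, where replacing the cyano by either a hydroxymethyl or a carbamoyl chain moved the number up to the limit. Compound 4 keeps an amide chain and adds a hydroxyl, and is therefore expected to stay at or close to the limit, with the step of a number no higher from compound 3 to compound 4 (the limit leaves the size open) expected to be small. The estimate for compound 4 is 100000 nM, with a range from 30000 nM to 100000 nM.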

Compound 4, half-maximal cytotoxic concentration: > 100000 nM
Compound 4 gave a limit, no number; the forecaster's own chance of this, stated with the estimate: 70%; the middle value sits exactly at the limit.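

The cyano group at this position has now given way to a third chain, 2-((2-hydroxyethyl)carbamoyl)ethyl, and in this assay the outcome again points upward, with an at least 4.4-fold higher number from compound 1 to compound 4 (0.64 log units; beyond the scatter). The entering chain contains no sulfur, so among the compounds shown, the methylsulfonyl group is not required for this upward step, and a chain ending in a hydroxyl group can also reach the limit of the assay. The steps among compound 2, compound 3 and compound 4 cannot be read, and no order among these three can be given, because all of them sit at the same limit: the limit of > 100000 nM in this assay, at which 3 of the 4 values shown sit.

How far the hydroxymethyl and the two amide chains differ from one another remains hidden beyond that limit, and only compound 1 gives an actual number against which a change can be sized. On these data alone, whether a chain ending in an amine or a carboxylic acid, or a simple methyl group at this position, would give a number like that of compound 1 or reach the same limit remains open.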